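Changing the Aryl Group and Expected Cell Toxicity

This account rests on a few compounds, and the source may have more. Where it says the series, first, only, none or still open, it means among the compounds named here.

Compound 1, `CS(=O)(=O)c1ccc(-n2c(=O)n(Cc3cc4cc(Cl)ccc4n3CCCC#N)c3cnccc32)cc1`: > 50000 nM
Compound 2, `CS(=O)(=O)CCCn1c(Cn2c(=O)n(C3CC3)c3ccncc32)cc2ccccc21`: > 100000 nM

Of the compounds shown here, two have been tested in an ADME assay on HeLa cells (Homo sapiens) for cytotoxicity, read by ATP content, with a stated time of 3 days; on this read-out higher numbers stand for lower toxicity in this test and lower numbers for higher toxicity in this test. Compound 1 gives > 50000 nM, which is a limit of the assay rather than a number. Compound 2 gives > 100000 nM, also a limit rather than a number. So compound 1 stands only at a limit, and the one other value shown is a limit as well; it sits at the limit of > 100000 nM in this assay, at which 1 of the 2 values shown sits, while compound 1 sits at the limit of > 50000 nM in this assay, at which 1 of the 2 values shown sits. Neither compound showed measurable toxicity to the cells within the tested range.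

Compound 3, `COc1ccc(-n2c(=O)n(Cc3cc4cc(Cl)ccc4n3CCCC#N)c3cnccc32)c(C)c1`, shares the core of compound 1 and differs in one place: 4-methoxy-2-methylphenyl in place of 4-(methylsulfonyl)phenyl on an aromatic nitrogen. Among the compounds with values here, since no step between two measured compounds is known, and both measured compounds sit at limits, there is no basis for expecting a large move in this assay in either direction beyond the scatter. Compound 3 is therefore expected to give 40000 nM, within a range from 8000 nM to 100000 nM, with the expected step of an at least 1.2-fold lower number from compound 1 to compound 3 (0.09 log units; that floor lies within the scatter).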

Compound 3, half-maximal cytotoxic concentration: > 50000 nM
Compound 3 was reported as a limit (the forecaster's own chance of this, stated with the estimate: 60%); at least 1.2-fold (0.09 log units) between middle value and limit.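

Compound 1 and compound 3 are both reported only as limits in this assay, and the step between them cannot be read. From the compounds shown here alone, it remains open whether 4-methoxy-2-methylphenyl in place of 4-(methylsulfonyl)phenyl changes toxicity to these cells at all, and at what concentration either compound would begin to show it.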